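The source may hold more compounds than are shown below. What is called first, only, known or untested is meant among the compounds shown, and "the series" means these compounds.

Working notes on the series. Compound 1 `CC#CC(CC(=O)O)c1ccc(OCC2COc3ccc(Cl)cc3O2)cc1`, compound 2 `CC#C[C@@H](CC(=O)O)c1ccc(OC[C@H]2COc3ccccc3O2)cc1` and compound 3 `CC#C[C@@H](CC(=O)O)c1ccc(OC[C@H]2COc3ccc(F)cc3O2)cc1` share one core and differ at the aromatic carbon of the fused ring system. In a functional assay on HEK293 cells for agonist activity at Free fatty acid receptor 1 (Homo sapiens), read by fluorescence and calcium flux, with a stated time of 10 min (on this read-out higher numbers stand for larger maximal responses and lower numbers for smaller maximal responses), compound 1 gives 104%, compound 2 gives 70% and compound 3 gives 86%. Compound 3 thus holds the second highest of the three numbers; the nearest is compound 2, lower beyond the scatter, and the furthest is compound 1, higher beyond the scatter.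

Compound 4 `CC#C[C@@H](CC(=O)O)c1ccc(OC[C@H]2COc3ccc(C)cc3O2)cc1` is not yet measured. Relative to compound 3 the change is methyl in place of fluoro on an aromatic carbon. Among the measured compounds shown here, the one measured step at this site is a number 16 percentage points higher from compound 2 to compound 3 (beyond the scatter), a modest rise. For the measured compounds named here, for compound 1 no step to compound 3 is computed; the two values merely show compound 1 with chloro at the higher number. Nothing measured exchanges fluoro for methyl. Given the rise from hydrogen to fluoro, a further small rise or no change beyond the scatter is expected. Compound 4 is expected to give 92% in this assay, between 76% and 108%. The expected step of a number 6 percentage points higher from compound 3 to compound 4 (within the scatter) would lie within the usual scatter.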

Compound 4, largest response reached (Emax), in percent of the reference or control that the assay uses: 78%
Estimate against measurement, compound 4: 14 percentage points above; the measured number falls inside the stated range.
By their numbers in this assay, from the lowest: compounds 2, 4 and 3 (each within the scatter of the next, the first and the last beyond it); then compound 1.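

In this assay, methyl at this aromatic carbon gives a number 8 percentage points lower from compound 3 to compound 4 (within the scatter) and a number 8 percentage points higher from compound 2 to compound 4 (within the scatter), so neither step separates methyl from fluoro or from hydrogen. Among the compounds shown here, the step for fluoro in place of hydrogen, a number 16 percentage points higher from compound 2 to compound 3 (beyond the scatter), remains the only step at this position beyond the scatter, and adding methyl gives no simple order across the three groups. No available evidence bears on the reason for these numbers.

Compound 1 carries chloro at this aromatic carbon, but it differs from the other compounds in more than one place, so its 104% cannot be assigned to chloro alone. From the compounds shown here alone, how a methoxy, trifluoromethyl or nitrile group at this aromatic carbon would read against hydrogen, fluoro and methyl remains open.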